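Dropping One Methoxy from the Carbonyl-Side Ring

The source may report more compounds than this note shows. Statements on the series, on what has been measured and on what is new or still open speak of the compounds shown alone.

Compound 1, `COc1cc(-c2cc(/C=C/C(=O)c3ccc(N)cc3)[nH]n2)cc(OC)c1OC`, gives 1690 nM in a functional assay on SF-268 cells (Homo sapiens) for inhibition, read by sulforhodamine B assay, with a stated time of 48 h; a higher number here means a weaker inhibitor of growth, a lower number a stronger inhibitor of growth.
Compound 2, `COc1cc(-c2cc(/C=C/C(=O)c3ccc(Cl)c(Cl)c3)[nH]n2)cc(OC)c1OC`, gives 13700 nM in this assay.
Compound 3, `COc1ccc(C(=O)/C=C/c2cc(-c3cc(OC)c(OC)c(OC)c3)n[nH]2)cc1OC`, gives 1820 nM in this assay.

These three share one core and differ only in the ring attached to the carbonyl carbon. Compound 3 stands second highest of the three numbers, but its value and that of compound 1 lie within the scatter of each other, so no order between them can be claimed; only a 7.5-fold lower number from compound 2 to compound 3 (0.88 log units; beyond the scatter) sets compound 3 clearly apart. The remaining measured steps, an 8.1-fold higher number from compound 1 to compound 2 (0.91 log units; beyond the scatter) and a 1.1-fold higher number from compound 1 to compound 3 (0.03 log units; within the scatter), show that exchanging the whole ring moves the number by a modest amount at most, and sometimes not at all.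

Compound 4, `COc1ccc(C(=O)/C=C/c2cc(-c3cc(OC)c(OC)c(OC)c3)n[nH]2)cc1`, is compound 3 with a single change: hydrogen in place of methoxy on an aromatic carbon. Among the measured compounds shown here, no measured step removes just one methoxy; every comparison available swaps the entire ring. Given that even such whole-ring swaps stayed modest, for compound 4 the expected step is a 1.4-fold higher number from compound 3 to compound 4 (0.14 log units; within the scatter) in this assay, small and without a clear direction beyond the scatter. Compound 4 is therefore estimated at 2500 nM, with a range from 900 nM to 7000 nM.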

Compound 4, concentration for 50% growth inhibition: 1990 nM
For compound 4 the middle estimate is 1.3-fold (0.10 log units) above the measured one; low and high end bracket the measured number.
By their numbers in this assay, from the lowest: compounds 1, 3 and 4 (each within the scatter of the next); then compound 2.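

In this assay, among the compounds shown here, this is the first change of a single group on the ring attached to the carbonyl carbon, rather than an exchange of the whole ring, and it gives a 1.1-fold higher number from compound 3 to compound 4 (0.04 log units; within the scatter). The methoxy lost in going from 3,4-dimethoxyphenyl to 4-methoxyphenyl can therefore be removed without a readable shift in growth inhibition, provided the other methoxy stays in place. Compound 4 also matches compound 1, which carries an amino group in place of its remaining methoxy, with a 1.2-fold higher number from compound 1 to compound 4 (0.07 log units; within the scatter), whereas the 3,4-dichlorophenyl ring of compound 2 stands apart, with a 6.9-fold lower number from compound 2 to compound 4 (0.84 log units; beyond the scatter).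

Nothing available explains why the two methoxy compounds and the amino compound sit so close together, or why compound 2 differs from them. On these data alone, it remains open whether a plain phenyl ring with no methoxy at all, or a hydroxyl group, a single chlorine atom or a carboxylic acid in place of the remaining methoxy, would also stay within the scatter of compound 4 or would move toward compound 2.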